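A few compounds are considered here, and "the series" means these few. Any claim that something is new, unique, unknown or untested is made for them only; others in the source may bear on it.

In a functional assay on HCT-15 cells (Homo sapiens) for cytotoxicity, read by sulforhodamine B assay, with a stated time of 72 h (on this read-out higher numbers stand for weaker inhibition of growth and lower numbers for stronger inhibition of growth), compound 1 `O=C(Nc1ccccc1C(F)(F)F)C1CCc2ccccc2N1C(=O)c1cccc(Cl)c1` gives 797 nM, the lowest of the three numbers on record. The nearest of the others is compound 3 `O=C(Nc1cc(C(F)(F)F)cc(C(F)(F)F)c1)C1CCc2ccccc2N1C(=O)c1ccccc1Cl`, which in this assay gives 4050 nM, a gap beyond the usual scatter; furthest is compound 2 `COc1ccc(NC(=O)C2CCc3ccccc3N2)cc1`, which in this assay gives 50200 nM, a gap also well beyond the scatter. Compound 1 thus stands as the strongest inhibitor of growth among the three.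

Compound 4 `O=C(Nc1ccccc1C(F)(F)F)C1CCc2ccccc2N1` has not yet been measured in this assay. It differs from compound 1 in one place: hydrogen in place of (3-chlorophenyl)carbonyl on a nitrogen on an aromatic ring in a ring. Among the measured compounds shown here, no pair of measured compounds differing in only one place is available, so the size of this step cannot be read off directly. For the measured compounds named here, the only hint comes from compound 2, whose ring nitrogen likewise carries only hydrogen and which in this assay gives 50200 nM, far weaker than compound 1; compound 2 differs elsewhere as well, so it is an imperfect guide.

On that basis the step is expected to go toward weaker inhibition of growth, and by a large margin, so that the step from compound 1 to compound 4 is estimated at a 25-fold higher number from compound 1 to compound 4 (1.40 log units; beyond the scatter). Compound 4 is therefore expected to give about 20000 nM in this assay, with a plausible range from 5000 nM to 80000 nM.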

Compound 4, concentration for 50% growth inhibition: 40400 nM
Compound 4: middle estimate off by 2.0-fold (0.31 log units), on the low side; low and high end bracket the measured number.
By their numbers in this assay, from the lowest: compound 1; then compound 3; then compounds 4 and 2 (each within the scatter of the next).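

In this assay, among the compounds shown here, the step of a 51-fold higher number from compound 1 to compound 4 (1.70 log units; beyond the scatter) gives the first direct reading at this position, and it is a large loss of growth inhibition. For the compounds shown here, the earlier compounds offered only an indirect hint, as compound 2 also carries hydrogen on the ring nitrogen but differs elsewhere, whereas this pair isolates the single exchange of (3-chlorophenyl)carbonyl for hydrogen on the core of compound 1. The group on this nitrogen therefore matters strongly for the activity of compound 1, but nothing on hand bears on the reason for the loss.

The compounds shown leave open whether the carbonyl alone would retain any of this activity, as an acetyl group might test, or whether the aromatic ring would do so when attached through a different link, as in a benzyl or benzenesulfonyl group. They also leave open how much the chlorine contributes, since neither an unsubstituted benzoyl group nor a methoxybenzoyl group appears on this core among them.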